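From an isopropoxy chain to a plain butyl chain

The source may hold more compounds than are shown below. What is called first, only, known or untested is meant among the compounds shown, and "the series" means these compounds.

Within the data shown here, in a functional assay on FaDu cells (Homo sapiens) for cytotoxicity, read by MTT assay, with a stated time of 72 h (a lower number here means that less compound is tolerated, a higher number that more compound is tolerated), compound 3 `COc1ccc(NC(=O)C(=O)c2cn(CCOC(C)C)c3ccccc23)cn1` gives 211 nM, the highest of the three numbers measured so far. Compound 1 `CCC(C)n1cc(C(=O)C(=O)Nc2ccc(OC)nc2)c2ccccc21` gives 68 nM, and compound 2 `COCC(C)n1cc(C(=O)C(=O)Nc2ccc(OC)nc2)c2ccccc21` gives 12 nM. Compound 3 stands clearly apart from both, with a 3.1-fold higher number from compound 1 to compound 3 (0.49 log units; beyond the scatter) and an 18-fold higher number from compound 2 to compound 3 (1.25 log units; beyond the scatter).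

Compound 4 `CCCCn1cc(C(=O)C(=O)Nc2ccc(OC)nc2)c2ccccc21` has not yet been measured. It differs from compound 3 by a single change, ethyl in place of isopropoxy on a saturated chain carbon, two bonds along the chain from an aromatic nitrogen. This leaves butyl on the aromatic nitrogen.

The closest guide is compound 1, which carries sec-butyl there and so has an all-carbon chain like compound 4. Its step to compound 3 suggests that the number should fall on leaving the isopropoxy chain. The evidence is mixed, however, as a 5.7-fold lower number from compound 1 to compound 2 (0.75 log units; beyond the scatter) shows an ether-bearing chain with the lower number, so compound 2 goes against any simple reading.

A modest step down in this assay is therefore expected, towards the value of compound 1. The expected step is a 2.6-fold lower number from compound 3 to compound 4 (0.42 log units; beyond the scatter). For compound 4 the estimate is 80 nM, with an expected range of 25 nM to 230 nM.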

Compound 4, concentration lethal to 50% of the cells: 18 nM
The estimate for compound 4 lay 4.4-fold (0.65 log units) above the measured number, and the stated range ends above it.
By their numbers in this assay, from the lowest: compounds 2 and 4 (each within the scatter of the next); then compound 1; then compound 3.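

The step of a 12-fold lower number from compound 3 to compound 4 (1.07 log units; beyond the scatter) in this assay shows that this position can respond strongly when isopropoxy gives way to ethyl, leaving butyl on the aromatic nitrogen. An ether oxygen in the chain does not by itself set the number, however: a 1.5-fold higher number from compound 2 to compound 4 (0.18 log units; within the scatter), so the ether-bearing chain of compound 2 and the all-carbon butyl chain cannot be told apart here, and only compound 3 among the ether-bearing compounds has a high number. The two all-carbon chains also differ, with a 3.8-fold lower number from compound 1 to compound 4 (0.58 log units; beyond the scatter), which shows that moving from sec-butyl to butyl on the aromatic nitrogen is enough to change the result beyond the scatter, even with no oxygen involved.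

The compounds shown leave open whether a 2-methoxyethyl chain or a longer chain such as hexyl on the aromatic nitrogen would stay close to compound 4 or move towards compound 3. Nothing available explains why these chains give such different numbers.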